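Swapping a Chloroalkyl Chain for a Bromoalkenyl Chain

A few compounds are considered here, and "the series" means these few. Any claim that something is new, unique, unknown or untested is made for them only; others in the source may bear on it.

Compound 1 `COc1ccc(CN(C(=O)C2CC2)c2cc(OC)c(OC)c(OC)c2)cc1O`, compound 2 `COc1ccc(CN(C(=O)C[Se]C#N)c2cc(OC)c(OC)c(OC)c2)cc1O` and compound 3 `COc1ccc(CN(C(=O)CCCCCl)c2cc(OC)c(OC)c(OC)c2)cc1O` share one core and differ only in the group attached to the carbonyl carbon. In a functional assay on HCT-116 cells (Homo sapiens) for inhibition, read by MTT assay, with a stated time of 48 h (on this read-out lower numbers stand for stronger inhibition and higher numbers for weaker inhibition), compound 1 gives 49 nM, compound 2 gives 310 nM and compound 3 gives 220 nM. Among these three numbers compound 3 stands second highest: its nearest neighbour is compound 2, separated by a 1.4-fold lower number from compound 2 to compound 3 (0.15 log units; within the scatter), and its furthest is compound 1, separated by a 4.5-fold higher number from compound 1 to compound 3 (0.65 log units; beyond the scatter).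

Compound 4 `COc1ccc(CN(C(=O)/C=C/CBr)c2cc(OC)c(OC)c(OC)c2)cc1O` has not yet been measured. 3-bromoprop-1-en-1-yl in place of 4-chlorobutyl on a carbonyl carbon Both the leaving and the entering groups are open halogen-bearing chains; the entering one is shorter and holds a double bond.

Among the measured compounds shown here, two measured steps touch this position. The step of a 4.5-fold higher number from compound 1 to compound 3 (0.65 log units; beyond the scatter) shows that moving from cyclopropyl to an open chain raised the number, while a 1.4-fold lower number from compound 2 to compound 3 (0.15 log units; within the scatter) shows that two different open chains gave numbers close to each other. For the measured compounds named here, no measured step exchanges one open chain for another of different length or with a double bond, so the direction is uncertain. The change is therefore expected to stay within the scatter in this assay, as no change at the digits printed from compound 3 to compound 4 (within the scatter). Compound 4 is estimated at 220 nM, with a range from 70 nM to 700 nM.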

Compound 4, half-maximal inhibitory concentration: 59 nM
Compound 4: middle estimate off by 3.7-fold (0.57 log units), on the high side; the measured number lies below the stated range.
By their numbers in this assay, from the lowest: compounds 1 and 4 (each within the scatter of the next); then compounds 3 and 2 (each within the scatter of the next).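

In this assay, putting 3-bromoprop-1-en-1-yl in place of 4-chlorobutyl on the carbonyl carbon gives a clear step (with a 3.7-fold lower number from compound 3 to compound 4 (0.57 log units; beyond the scatter)), and the same chain also separates from the selenium-bearing chain of compound 2 (with a 5.3-fold lower number from compound 2 to compound 4 (0.72 log units; beyond the scatter)). Until now the two open chains had numbers close to each other and both lay clearly above the cyclopropyl compound, but this open chain stands level with the ring (with a 1.2-fold higher number from compound 1 to compound 4 (0.08 log units; within the scatter)), so a ring is not required at this position for a number as low as that of compound 1. Nothing measured here explains why this chain differs from the other two open chains.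

The step from compound 3 to compound 4 changes the chain length, the double bond and the halogen all at once, so the compounds shown cannot say which of these matters, or whether they matter only in combination. A saturated 3-bromopropyl chain, a 3-chloroprop-1-en-1-yl chain and a 4-bromobutyl chain would each pull these changes apart.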